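Swapping the aryl group on the urea nitrogen

This account rests on a few compounds, and the source may have more. Where it says the series, first, only, none or still open, it means among the compounds named here.

Within the data shown here, compound 1, `N#Cc1cccc([C@]23CCC(N(CCN4CC[C@@H](O)C4)C(=O)Nc4cc(F)cc(F)c4)CC2C3)c1`, gives 15 nM in a functional assay for antagonist activity at melanin-concentrating hormone receptor 1 (Homo sapiens); a higher number here means a weaker inhibitor, a lower number a stronger inhibitor; this is the lowest of the two numbers measured so far. Compound 2, `N#Cc1cccc([C@]23CCC(N(CCN4CC[C@@H](O)C4)C(=O)Nc4cccc(Cl)c4)CC2C3)c1`, gives 27 nM in this assay, and the change a 1.8-fold higher number from compound 1 to compound 2 (0.26 log units; within the scatter) lies within the scatter. Compound 3, `N#Cc1cccc(NC(=O)N(CCN2CC[C@@H](O)C2)C2CC[C@]3(c4cccc(C#N)c4)CC3C2)c1`, has not yet been measured in this assay. It differs from compound 1 in one place: 3-cyanophenyl in place of 3,5-difluorophenyl on an amide-type nitrogen. Among the measured compounds shown here, only one measured step touches this same aryl group, the step from compound 1 to compound 2, and it stayed within the scatter. Nothing measured here speaks for a step beyond the scatter in either direction, so compound 3 is expected to sit close to compound 1, with the estimated change a 1.3-fold higher number from compound 1 to compound 3 (0.12 log units; within the scatter). On that basis compound 3 is estimated at 20 nM in this assay, with a range from 7 nM to 60 nM.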

Compound 3, inhibition constant: 92 nM
Compound 3: middle estimate off by 4.6-fold (0.66 log units), on the low side; the measured number lies above the stated range.
By their numbers in this assay, from the lowest: compounds 1 and 2 (each within the scatter of the next); then compound 3.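

The aryl group on the urea nitrogen is not indifferent to what it carries. In this assay the nitrile brings a real loss, with a 6.1-fold higher number from compound 1 to compound 3 (0.79 log units; beyond the scatter) and a 3.4-fold higher number from compound 2 to compound 3 (0.53 log units; beyond the scatter), both beyond the scatter, whereas the earlier swap between the two halogen-bearing rings stayed within it. So among these three compounds the two halogen-bearing rings sit together and the nitrile-bearing ring of compound 3 sits apart, but nothing measured alongside these numbers says why.

From the compounds shown here alone, it remains open whether this loss is particular to the nitrile or extends to other non-halogen groups. A methyl group, a methoxy group or an amine in place of the cyano on this phenyl ring would help to separate those two readings.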